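The source may hold more compounds than are shown below. What is called first, only, known or untested is meant among the compounds shown, and "the series" means these compounds.

Compound 2 `c1ccc(Sc2c(-c3ccccc3)nc3ccc(-c4ccccc4)cn23)cc1` gives 54200 nM in a functional assay on A549 cells (Homo sapiens) for inhibition, read by MTT assay, with a stated time of 48 h; on this read-out lower numbers stand for stronger inhibition and higher numbers for weaker inhibition. Among the three compounds measured so far, compound 2 stands second highest; compound 1 `CCc1ccc(-c2nc3ccccn3c2Sc2ccccc2)cc1` gives 56200 nM, a number within the scatter of that of compound 2, while compound 3 `CSc1ccc(-c2nc3ccccn3c2Sc2ccccc2)cc1` gives 13600 nM, the lowest of the three. Going by the values given here, the one step that can be followed within the measured set runs between compound 1 and compound 3, a 4.1-fold lower number from compound 1 to compound 3 (0.62 log units; beyond the scatter), and its change sits elsewhere on the structure than the fused system. Compound 4 `Clc1ccc2nc(-c3ccccc3)c(Sc3ccccc3)n2c1` differs from compound 2 at a different place: chloro in place of phenyl on an aromatic carbon, that is, on an aromatic carbon of the six-membered aromatic ring with one nitrogen in the fused system, two atoms from the ring nitrogen. Among the compounds with values here, no measured step touches that ring, so the step from compound 1 to compound 3 bears on it only as a sign that a single change of group can move the number by a modest amount. With nothing measured at the fused system itself, the expected step is none beyond the scatter, and the number for compound 4 is estimated at 45000 nM, with a range from 15000 nM to 130000 nM. The step that this estimate means, a 1.2-fold lower number from compound 2 to compound 4 (0.08 log units; within the scatter), is expected to stay within the scatter.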

Compound 4, half-maximal inhibitory concentration: 24400 nM
Compound 4: middle estimate off by 1.8-fold (0.27 log units), on the high side; low and high end bracket the measured number.
By their numbers in this assay, from the lowest: compounds 3 and 4 (each within the scatter of the next); then compounds 2 and 1 (each within the scatter of the next).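

In this assay, going by these compounds alone, the step from phenyl to chloro on an aromatic carbon of the six-membered aromatic ring with one nitrogen, two atoms from the ring nitrogen, gives a 2.2-fold lower number from compound 2 to compound 4 (0.35 log units; beyond the scatter), the first measured step at the fused system, and a modest one. It shows that this carbon is not silent in the series and that the phenyl group is not needed there for a number at this level, since a single chlorine atom in place of a whole six-carbon aromatic ring gives the lower number. The compounds come with no separate measurement bearing on this step, so the data offer no explanation for it.

On these data alone, with only phenyl and chloro compared at this carbon, it remains open whether the step follows from the loss of the ring or from the arrival of the chlorine, and an amine or a methyl group at the same carbon would help to separate the two. As far as these compounds go, it is also open whether chloro in place of phenyl at this position would move the number in the same direction with the methylsulfanyl group of compound 3 on the shared core.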